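This account rests on a few compounds, and the source may have more. Where it says the series, first, only, none or still open, it means among the compounds named here.

Measured so far:
Compound 1, `COC(=O)c1ccc(C2SCC(=O)N2c2ccc(N3CCN(S(=O)(=O)c4ccc(F)cc4)CC3)cn2)c(OC)c1` — > 100000 nM
Compound 2, `COC(=O)c1ccc(C2SCC(=O)N2c2ccc(N3CCN(Cc4ccc(Cl)c(Cl)c4)CC3)cn2)c(OC)c1` — > 100000 nM

Compound 2 stands at the edge of what can be measured. In a functional assay on K562 cells (Homo sapiens) for antiproliferative activity, read by MTT assay and trypan blue exclusion, with a stated time of 72 h (a lower number here means a stronger inhibitor, a higher number a weaker inhibitor), compound 2 gives only a limit, > 100000 nM, not a number. Compound 1 likewise gives only a limit in this assay, > 100000 nM. Going by the values given here, the one measured step, a step that the two limits leave unreadable from compound 1 to compound 2, therefore cannot be read, because both of its ends sit at the limit of > 100000 nM in this assay, at which 2 of the 2 values shown sit.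

The next compound, compound 3, `COC(=O)c1ccc(C2SCC(=O)N2c2ccc(N3CCN(S(=O)(=O)c4ccccc4)CC3)cn2)c(OC)c1`, differs from compound 2 by phenylsulfonyl in place of 3,4-dichlorobenzyl on an amine nitrogen in a ring. No readable step bears on this change, so there is no measured size to carry over; what the two measured compounds show is that each sits at the limit. Compound 3 is therefore expected to sit at the limit as well, with an estimate of 150000 nM in this assay and a range of 50000 nM to 500000 nM. The step that the limit leaves unreadable from compound 2 to compound 3 that this estimate implies is expected to be unreadable in the same way.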

Compound 3, half-maximal inhibitory concentration: 65600 nM
Beside the measured number, compound 3's estimate is 2.3-fold (0.36 log units) above it; low and high end bracket the measured number.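

With phenylsulfonyl on the amine nitrogen in the ring, compound 3 is the first compound shown to give a number rather than a limit in this assay. Two steps lead to it: phenylsulfonyl in place of 3,4-dichlorobenzyl gives an at least 1.5-fold lower number from compound 2 to compound 3 (0.18 log units; that floor lies within the scatter), and hydrogen in place of fluoro on an aromatic carbon gives an at least 1.5-fold lower number from compound 1 to compound 3 (0.18 log units; that floor lies within the scatter). Each step is known only as a floor, and its true size stays unknown, because the other end of each sits at a limit: the limit of > 100000 nM in this assay, at which 2 of the 3 values shown sit.

The compounds shown leave open whether a methoxy group on the aromatic ring of the phenylsulfonyl, or an acetyl group on the same amine nitrogen, would also give a number. They also leave open how a carboxylic acid in place of the ester would change the result.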